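Swapping anilino for cyclopentyl(methyl)amino on a sulfonyl

This account rests on a few compounds, and the source may have more. Where it says the series, first, only, none or still open, it means among the compounds named here.

Compound 1 `O=C(NCc1ccncc1)Nc1ccc(S(=O)(=O)Nc2ccccc2)cc1` is the more active of the two measured compounds in an assay on isolated protein for activation of Nicotinamide phosphoribosyltransferase (Homo sapiens) (a higher number here means that more compound is needed for the effect, a lower number that less compound is needed), where compound 1 gives 410 nM. Compound 2 `CCOC(=O)c1ccc(NC(=S)NCc2ccncc2)cc1` gives 9770 nM in this assay, a far higher number; the two structures differ in more than one place, so only their two values can be set side by side. Compound 3 `CN(C1CCCC1)S(=O)(=O)c1ccc(NC(=O)NCc2ccncc2)cc1` differs from compound 1 in a single place: cyclopentyl(methyl)amino in place of anilino on a sulfonyl sulfur. Among the compounds with values here, no measured pair shows what such a change does here, so its size is uncertain. Since compound 1 stands at 410 nM and the change trades the aromatic ring and the hydrogen-bond donor for a five-membered non-aromatic ring, compound 3 is expected to need somewhat more compound, with the step of a 2.9-fold higher number from compound 1 to compound 3 (0.47 log units; beyond the scatter) expected to lie a little beyond the scatter. Compound 3 is accordingly estimated at 1200 nM, within a range from 400 nM to 4000 nM.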

Compound 3, half-maximal effective concentration: 123 nM
Compound 3: the middle estimate sits 9.8-fold (0.99 log units) above what was measured; the measured number lies below the stated range.
By their numbers in this assay, from the lowest: compound 3; then compound 1; then compound 2.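

In this assay, within the data shown here, the step of a 3.3-fold lower number from compound 1 to compound 3 (0.52 log units; beyond the scatter) gives the first measured reading of a change on the sulfonyl sulfur, and it runs towards less compound needed. Anilino is therefore not required at this place: with cyclopentyl(methyl)amino, the core of compound 1 keeps its activity and improves on it, even without the six-membered aromatic ring and the hydrogen-bond donor of anilino. No evidence is available to explain why the number falls.

The compounds shown leave open which part of the exchange matters, since the aromatic ring and the donor leave together and the five-membered ring and the methyl group enter together. Methyl(phenyl)amino or cyclopentylamino on the same sulfur would separate these parts, and how far the gain extends to larger rings such as piperidinyl also remains open.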